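The source may hold more compounds than are shown below. What is called first, only, known or untested is meant among the compounds shown, and "the series" means these compounds.

Working notes on a set of four compounds built on two cores, each bearing two methoxy-substituted aryl groups, assessed in a functional assay on A549 cells (Homo sapiens) for cytotoxicity, read by MTT assay, with a stated time of 72 h; a lower number here means a stronger inhibitor, a higher number a weaker inhibitor.

Compound 1 `COc1ccccc1/C=C1\CCC/C(=C\c2cccc(OC)c2OC)C1=O` opens the set. In this assay compound 1 gives > 20000 nM, which is a limit of the assay and not a number.

Compound 2 `COc1cccc(/C=C2\CCC/C(=C\c3cccc(OC)c3OC)C2=O)c1` differs from compound 1 by 3-methoxyphenyl in place of 2-methoxyphenyl on a double-bonded chain carbon bound to a double-bonded ring carbon. In this assay compound 2 gives 16400 nM. The step recorded is an at least 1.2-fold lower number from compound 1 to compound 2 (0.08 log units; that floor lies within the scatter); its floor lies within the scatter and is set by the limit of > 20000 nM in this assay, at which 2 of the 3 values shown sit, so the true size of the step is not known.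

Compound 3 `COc1ccccc1/C=C1\CCC/C(=C\c2ccc(OC)c(OC)c2)C1=O` stands on the second core; the difference between the two cores is not broken down here. In this assay compound 3 gives > 20000 nM, again a limit of the assay and not a number.

Compound 4 `COc1cccc(/C=C2\CCC/C(=C\c3ccc(OC)c(OC)c3)C2=O)c1` is the unmeasured member. Compound 4 differs from compound 3 by 3-methoxyphenyl in place of 2-methoxyphenyl on a double-bonded chain carbon bound to a double-bonded ring carbon, the same change as between compound 1 and compound 2, here made on the second core. In this assay the step from compound 3 to compound 4 is expected to be a number no higher from compound 3 to compound 4 (the limit leaves the size open). That expectation rests on an at least 1.2-fold lower number from compound 1 to compound 2 (0.08 log units; that floor lies within the scatter), a step whose floor lies within the scatter, and on (the limit of > 20000 nM in this assay, at which 2 of the 3 values shown sit). Compound 4 is therefore expected to give about 20000 nM in this assay, with a range from 10000 nM to 50000 nM, and a fair chance that only a limit is reported.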

Compound 4, half-maximal inhibitory concentration: 6700 nM
Compound 4: the middle estimate sits 3.0-fold (0.47 log units) above what was measured, and the stated range ends above it.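

In this assay, 3-methoxyphenyl in place of 2-methoxyphenyl on a double-bonded chain carbon bound to a double-bonded ring carbon gives an at least 2.9-fold lower number from compound 3 to compound 4 (0.47 log units; beyond the scatter), so on the core of compound 3 the change has an effect that clears the scatter. Set beside the earlier step, the change runs in the same direction on both cores, though only on the core of compound 3 does the floor of the step lie beyond the scatter: the same change on two cores in this assay, an at least 1.2-fold lower number (0.08 log units; that floor lies within the scatter) from compound 1 to compound 2 and an at least 2.9-fold lower number (0.47 log units; beyond the scatter) from compound 3 to compound 4; the limit leaves it open whether they differ This does not show that the change is worth the same on both cores, nor how large either step really is, because compound 1 and compound 3 each rest on a limit and not on a number: the limit of > 20000 nM in this assay, at which 2 of the 4 values shown sit.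

The compounds shown carry only methoxy groups on their aryl rings, so it stays open whether the step belongs to the 3-methoxyphenyl group specifically or would also appear with a 3-hydroxyphenyl or 3-chlorophenyl group in the same place. Also open, as far as these compounds go, is whether the same direction would hold on a core bearing an amine or a carboxylic acid on the second aryl ring.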